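A few compounds are considered here, and "the series" means these few. Any claim that something is new, unique, unknown or untested is made for them only; others in the source may bear on it.

Measured compounds:
compound 1, `Cc1ccccc1C(=O)NCc1ccc(CNS(=O)(=O)c2ccc(Cl)cc2)cc1`, in an assay on MDA-MB-231 cells for displacement of a labelled ligand from C-X-C chemokine receptor type 4 (Homo sapiens), read by fluorescence and microscopy, with stated times of 10 min and 30 min (on this read-out higher numbers stand for an effect only at larger amounts of compound and lower numbers for an effect already at smaller amounts), compound 1 gives 1 nM.
compound 2, `Cc1ccccc1C(=O)NCc1ccc(CNS(=O)(=O)c2ccccc2C)cc1`, compound 2 gives 10 nM.
compound 3, `COc1ccccc1C(=O)NCc1ccc(CNS(=O)(=O)c2ccc(Cl)cc2)cc1`, compound 3 gives 1000 nM.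

Compound 4, `COc1ccccc1C(=O)NCc1ccc(CNS(=O)(=O)c2ccccc2C)cc1`, has not yet been measured. It is reached from compound 3 by the change (2-methylphenyl in place of 4-chlorophenyl on a sulfonyl sulfur), which is the same change that separates compound 1 from compound 2, (2-methylphenyl in place of 4-chlorophenyl on a sulfonyl sulfur); the place of the change is described in the same words in both pairs. The two cores differ by methoxy in place of methyl on an aromatic carbon, and that difference alone brought a 1000-fold higher number from compound 1 to compound 3 (3.00 log units; beyond the scatter).

On the measured pair the change made a 10-fold higher number from compound 1 to compound 2 (1.00 log units; beyond the scatter). Carrying the same step over to compound 3, a step of about an 8.0-fold higher number from compound 3 to compound 4 (0.90 log units; beyond the scatter) is expected for compound 4 in this assay, because compound 3 already stands at 1000 nM and the weakening seen on compound 1 is assumed to repeat on the other core. Among the compounds with values here, only one instance of the change is measured, so the carry-over is uncertain, and with a starting value this high the read-out may run into the range of the assay. Compound 4 is estimated at 8000 nM, expected between 2000 nM and 30000 nM.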

Compound 4, effective concentration (reported as EC, without a stated level of effect): 1000 nM
The estimate for compound 4 lay 8.0-fold (0.90 log units) above the measured number; measured number outside the range, below it.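

In this assay, 2-methylphenyl in place of 4-chlorophenyl on the sulfonyl sulfur gave no change at the digits printed from compound 3 to compound 4 (within the scatter), so the step seen on the core of compound 1 did not carry over to the core of compound 3: the same change on two cores in this assay, a 10-fold higher number (1.00 log units; beyond the scatter) from compound 1 to compound 2 and no change at the digits printed (within the scatter) from compound 3 to compound 4, 10-fold (1.00 log units) apart, beyond the scatter of two such steps Methoxy in place of methyl on the aromatic carbon gave a 100-fold higher number from compound 2 to compound 4 (2.00 log units; beyond the scatter), still a large step but not the same size on the two sulfonyl groups: the same change on two cores in this assay, a 1000-fold higher number (3.00 log units; beyond the scatter) from compound 1 to compound 3 and a 100-fold higher number (2.00 log units; beyond the scatter) from compound 2 to compound 4, 10-fold (1.00 log units) apart, beyond the scatter of two such steps In these four compounds, then, the two changes do not add up and the size of each step depends on the other place, but one pair of cores shows neither why this happens nor whether it holds for other groups.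

Going by these compounds, it remains open whether an amine or a carboxylic acid on that aromatic carbon would behave like methyl or like methoxy. On these data alone, it is also open how a longer chain on the sulfonyl sulfur would read on either core.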